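Working notes: expected activity of compound 4

This account rests on a few compounds, and the source may have more. Where it says the series, first, only, none or still open, it means among the compounds named here.

Measured in an assay on cells for agonist activity at ecdysone receptor (Bombyx mori), read by a luciferase reporter, with a stated time of 24 h; a lower number here means that less compound is needed, a higher number that more compound is needed for the effect:
compound 1 `CCc1ccccc1C(=O)N(NC(=O)c1ccccc1)C(C)(C)C` gives 589 nM
compound 2 `CC(C)(C)N(NC(=O)c1ccccc1Cl)C(=O)c1ccccc1Cl` gives 331 nM
compound 3 `Cc1ccc(C(=O)NN(C(=O)c2ccccc2Cl)C(C)(C)C)cc1` gives 18.6 nM

Compound 2 holds the second highest of the three numbers; compound 1 sits within the scatter of it, while compound 3 lies far lower, the step being an 18-fold lower number from compound 2 to compound 3 (1.25 log units; beyond the scatter). Compound 4 `Cc1ccc(C(=O)NN(C(=O)c2ccccc2Cl)C(C)(C)C)c(C)c1` differs from compound 2 in one place: 2,4-dimethylphenyl in place of 2-chlorophenyl on a carbonyl carbon. Going by the values given here, the only step that bears on this is the one to compound 3, in which a methyl-bearing phenyl also replaced the 2-chlorophenyl on the same carbonyl carbon, giving a large lowering. The entering 2,4-dimethylphenyl of compound 4 resembles the 4-methylphenyl of compound 3, so a lowering of similar size is expected, a 13-fold lower number from compound 2 to compound 4 (1.12 log units; beyond the scatter). Compound 4 is therefore estimated at 25 nM, with a range of 8 nM to 90 nM.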

Compound 4, half-maximal effective concentration: 162 nM
For compound 4 the middle estimate is 6.5-fold (0.81 log units) below the measured one; measured number above the stated range.
By their numbers in this assay, from the lowest: compound 3; then compound 4; then compounds 2 and 1 (each within the scatter of the next).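

In this assay, 2,4-dimethylphenyl in place of 2-chlorophenyl on this carbonyl carbon gives only a 2.0-fold lower number from compound 2 to compound 4 (0.31 log units; beyond the scatter), so a methyl-bearing phenyl here does not by itself secure the large gain seen with 4-methylphenyl. The additional methyl on the aromatic ring gives an 8.7-fold higher number from compound 3 to compound 4 (0.94 log units; beyond the scatter), which gives back much of that gain. The result at this carbonyl carbon therefore depends on the full substitution of the phenyl, not merely on the presence of a methyl. As far as these compounds go, whether a methoxy group or a fluorine atom in place of the additional methyl would give a similar result stays open. Nothing available addresses the reason for this loss.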